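The compounds below may be only part of what the source reports. "The series", "measured", "known", "first", "only" and "open" are said of these compounds alone.

Measured so far in a functional assay on HEK293 cells for agonist activity at probable G-protein coupled receptor 27 (Homo sapiens), read by a luciferase reporter and beta-arrestin recruitment, with a stated time of 10 min; a lower number here means that less compound is needed, a higher number that more compound is needed for the effect:
compound 1 `Cc1cc(Cl)ccc1C(=O)Nc1ccc(S(=O)(=O)Nc2ccccc2)cc1`: 912 nM.
compound 2 `O=C(Nc1ccc(S(=O)(=O)Nc2ccc(Cl)cc2)cc1)c1ccc(Cl)cc1Cl`: > 100000 nM, a limit of the assay.
compound 3 `O=C(Nc1ccc(Cl)cc1Cl)c1ccc(S(=O)(=O)Nc2ccccc2)cc1`: > 100000 nM, a limit of the assay.

For the measured compounds named here, compound 1 carries the only number in this assay. Compound 2 stands at the limit of > 100000 nM in this assay, at which 2 of the 3 values shown sit, so no number is known for it. Compound 4 `O=C(Nc1ccc(S(=O)(=O)Nc2ccccc2Cl)cc1)c1ccc(Cl)cc1Cl` differs from compound 2 by 2-chlorophenyl in place of 4-chlorophenyl on a sulfonamide nitrogen. Going by the values given here, no measured pair isolates this change, so its size is open. The step from compound 2 to compound 4 is expected as an at least 3.3-fold lower number from compound 2 to compound 4 (0.52 log units; beyond the scatter), toward a lower number but of uncertain size, a guess resting on compound 1 with an unsubstituted phenyl on the sulfonamide nitrogen giving 912 nM. Compound 4 is expected near 30000 nM, within 2000 nM to 200000 nM, with a fair chance that this assay again reports only a limit.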

Compound 4, half-maximal effective concentration: 1260 nM
For compound 4 the middle estimate is 24-fold (1.38 log units) above the measured one; the measured number lies below the stated range.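

On the sulfonamide nitrogen, the place of the chlorine on the phenyl ring matters in this assay: with the same atoms otherwise, 2-chlorophenyl in place of 4-chlorophenyl gives an at least 79-fold lower number from compound 2 to compound 4 (1.89 log units; beyond the scatter). For the compounds shown here, this is the first pair to isolate a change at this position, and it shows that a chlorine-bearing phenyl here can keep a measurable number. The true size of the step stays unknown, as compound 2 gives only a limit: the limit of > 100000 nM in this assay, at which 2 of the 4 values shown sit.

Still open, on these data alone, is what the chlorine itself contributes to compound 4, relative to an unsubstituted phenyl with the rest of compound 4 unchanged. Also open, as far as these compounds go, is whether methoxy or fluorine can take the place of this chlorine.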